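Working notes: from compound 3 to compound 4

The compounds below may be only part of what the source reports. "The series", "measured", "known", "first", "only" and "open" are said of these compounds alone.

- compound 1 `O=C(Nc1ccc(I)cc1)Nc1nc(-c2cc3ccccc3o2)cs1` gives 62000 nM
- compound 2 `COc1ccc(NC(=O)Nc2nc(-c3cc4ccccc4o3)cs2)cc1` gives 17400 nM
- compound 3 `O=C(Nc1ccc([N+](=O)[O-])cc1)Nc1nc(-c2cc3ccccc3o2)cs1` gives 19300 nM

All three values come from a physicochemical assay, with a stated time of 6 min; on this read-out higher numbers stand for weaker inhibition and lower numbers for stronger inhibition. Compound 3 stands level with its nearest neighbour, with a 1.1-fold higher number from compound 2 to compound 3 (0.05 log units; within the scatter), and well under the highest number, with a 3.2-fold lower number from compound 1 to compound 3 (0.51 log units; beyond the scatter).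

The next compound is compound 4 `O=C(Nc1cccc(Cl)c1)Nc1nc(-c2cc3ccccc3o2)cs1`, which carries 3-chlorophenyl in place of 4-nitrophenyl on an amide-type nitrogen. The measured steps at this place are few. Two moves away from iodo gave modest changes, a 3.6-fold lower number from compound 1 to compound 2 (0.55 log units; beyond the scatter) and a 3.2-fold lower number from compound 1 to compound 3 (0.51 log units; beyond the scatter), while the move from methoxy to nitro gave a 1.1-fold higher number from compound 2 to compound 3 (0.05 log units; within the scatter). Within the data shown here, no measured step brings in 3-chlorophenyl, so the evidence is indirect.

Among the measured compounds shown here, the only measured compound with a halogen on this ring is compound 1 at 62000 nM, which leaves room for a modest rise, though a change of similar size in either direction cannot be excluded. In this assay the expected step is small, a 1.3-fold higher number from compound 3 to compound 4 (0.11 log units; within the scatter), and no shift beyond the scatter is firmly expected. The estimated value for compound 4 is 25000 nM, with an expected range from 10000 nM to 60000 nM.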

Compound 4, half-maximal inhibitory concentration: 14100 nM
Compound 4: middle estimate off by 1.8-fold (0.25 log units), on the high side; the measured number falls inside the stated range.
By their numbers in this assay, from the lowest: compounds 4, 2 and 3 (each within the scatter of the next); then compound 1.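

In this assay, 3-chlorophenyl on the amide-type nitrogen stands level with the two groups that had already matched each other, with a 1.4-fold lower number from compound 3 to compound 4 (0.14 log units; within the scatter) and a 1.2-fold lower number from compound 2 to compound 4 (0.09 log units; within the scatter), so three different aryl groups now sit within the scatter of one another. Among these compounds, the only step here beyond the scatter is a 4.4-fold lower number from compound 1 to compound 4 (0.64 log units; beyond the scatter), which shows that a halogen on this ring does not by itself go with the highest number, and compound 1 stays alone at the top of the set. Nothing measured here accounts for the separate standing of 4-iodophenyl or for the level standing of the other three groups.

3-Chlorophenyl and 4-iodophenyl differ both in the halogen and in its place on the ring, so the compounds shown do not tell which of the two goes with the gap. Also open, on these data alone, is how the number would respond to an amine or a carboxylic acid on this ring, or to a longer chain in place of the ring on the same nitrogen.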